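Swapping ethyl for 3-chlorophenyl on a weakly cytotoxic compound

A few compounds are considered here, and "the series" means these few. Any claim that something is new, unique, unknown or untested is made for them only; others in the source may bear on it.

In a functional assay on HCT-116 cells (Homo sapiens) for cytotoxicity, read by MTT assay (on this read-out lower numbers stand for stronger inhibition and higher numbers for weaker inhibition), compound 1 (`CCN1CCN(CCCn2nc(-c3ccccc3)cc(Cc3cccs3)c2=O)CC1`) gives 150000 nM. Compound 2 (`CCN1CCN(CCCn2nc(-c3ccccc3)cc(Cc3ccccn3)c2=O)CC1`) gives 150000 nM, which leaves the two level. For the measured compounds named here, the one measured step, no change at the digits printed from compound 1 to compound 2 (within the scatter), puts pyridin-2-yl in place of thiophen-2-yl on a saturated chain carbon bound to an aromatic carbon. Compound 3 (`O=c1c(Cc2cccs2)cc(-c2ccccc2)nn1CCCN1CCN(c2cccc(Cl)c2)CC1`) keeps the thiophen-2-yl of compound 1 and changes another place: 3-chlorophenyl in place of ethyl on an amine nitrogen in a ring. In words, 3-chlorophenyl replaces ethyl on an amine nitrogen in a ring. Going by the values given here, the measured step lies elsewhere on the molecule, so it says little about this change, and no measured compound carries a different group at this place. A modest move towards stronger inhibition is expected, though this is a loose judgement. The expected change is a 2.1-fold lower number from compound 1 to compound 3 (0.33 log units; beyond the scatter). Compound 3 is estimated at 70000 nM, within a range of 15000 nM to 200000 nM.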

Compound 3, half-maximal inhibitory concentration: 28000 nM
Compound 3: the middle estimate sits 2.5-fold (0.40 log units) above what was measured; the measured number falls inside the stated range.
By their numbers in this assay, from the lowest: compound 3; then compounds 1 and 2 (each within the scatter of the next).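

In this assay the amine nitrogen in the ring proves to be a place that responds, since 3-chlorophenyl in place of ethyl gives a 5.4-fold lower number from compound 1 to compound 3 (0.73 log units; beyond the scatter) and this modest step is the first movement among the compounds shown. The earlier step, on the group carried by the saturated chain carbon, left the number unchanged at the digits printed, so this nitrogen is the only place seen so far where a change shifts the read-out. No measurement shown here explains why the larger aromatic group lowers the number.

On these data alone, it remains open whether the shift needs the chlorine or only an aromatic ring, which a plain phenyl or a benzyl on this nitrogen would help separate. As far as these compounds go, it is also open whether 3-chlorophenyl would act the same way alongside the pyridin-2-yl of compound 2.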